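The source may report more compounds than this note shows. Statements on the series, on what has been measured and on what is new or still open speak of the compounds shown alone.

Measured in a functional assay on A549 cells (Homo sapiens) for antiproliferative activity, read by MTT assay, with a stated time of 72 h; a lower number here means a stronger inhibitor, a higher number a weaker inhibitor:
- compound 1 `O=C(N/N=C/c1cccc(Br)c1)Nc1ccc(Oc2ccnc3[nH]ccc23)c(F)c1`: 2220 nM
- compound 2 `O=C(N/N=C/c1ccc(O)cc1)Nc1ccc(Oc2ccnc3[nH]ccc23)c(F)c1`: 3760 nM
- compound 3 `O=C(N/N=C/c1ccc(O)cc1O)Nc1ccc(Oc2ccnc3[nH]ccc23)c(F)c1`: 5840 nM

Not yet measured: compound 4 `CN(C)CCn1cccc1/C=N/NC(=O)Nc1ccc(Oc2ccnc3[nH]ccc23)c(F)c1`.

Compound 3 cannot be separated from compound 2, given a 1.6-fold higher number from compound 2 to compound 3 (0.19 log units; within the scatter). It stands apart only from compound 1, given a 2.6-fold higher number from compound 1 to compound 3 (0.42 log units; beyond the scatter).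

The next step puts 1-(2-(dimethylamino)ethyl)-1H-pyrrol-2-yl in place of 2,4-dihydroxyphenyl on a carbon with a double bond to nitrogen.

Two measured steps change the group at this place: a 1.7-fold higher number from compound 1 to compound 2 (0.23 log units; within the scatter) and a 2.6-fold higher number from compound 1 to compound 3 (0.42 log units; beyond the scatter). Both are small, but all three measured groups are six-membered aromatic rings of carbon only, so the new group lies outside what has been tested. Within the data shown here, compound 1, which has no hydroxy group, gives the only separation from compound 3, so a modest move to a lower number is expected, with little confidence in its direction. In this assay the expected change is a 2.3-fold lower number from compound 3 to compound 4 (0.37 log units; beyond the scatter). For compound 4 the estimated value is 2500 nM, with an expected range of 700 nM to 8000 nM.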

Compound 4, half-maximal inhibitory concentration: "not active" (no number reported)
Compound 4: no number reported, so the estimate cannot be set against anything.
By their numbers in this assay, from the lowest: compounds 1, 2 and 3 (each within the scatter of the next, the first and the last beyond it).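

Among these compounds, compound 4 is reported as not active in this assay with no number, so no step from compound 3 can be read. The compounds shown leave open how a five-membered aromatic ring with 1 hetero atom compares at this place with the six-membered rings. Nothing given here bears on a cause.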